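From 4-methylphenyl to 4-bromophenyl

The source may hold more compounds than are shown below. What is called first, only, known or untested is meant among the compounds shown, and "the series" means these compounds.

The record for this small set of compounds in an ADME assay on HUVEC cells (Homo sapiens) for cytotoxicity, read by MTT assay, with a stated time of 72 h (on this read-out lower numbers stand for stronger inhibition and higher numbers for weaker inhibition), is thin. For compound 1 `CCn1ccnc1-c1cc(OC)c(OC)c(OC)c1` the entry reads "not determined" (no result reported) and offers no number to work with. For compound 2 `COc1cc(-c2nccn2CC(C)C)cc(OC)c1OC` the entry likewise reads "not determined" (no result reported) and gives nothing further. Compound 3 `COc1cc(-c2nccn2-c2ccc(C)cc2)cc(OC)c1OC` has a reported result of > 100000 nM which is a limit of the assay and not a number.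

Compound 4 `COc1cc(-c2nccn2-c2ccc(Br)cc2)cc(OC)c1OC` differs from compound 3 in one place, on an aromatic carbon of a six-membered aromatic ring of carbon only, para to a large group. Bromo stands there in place of methyl, so that 4-methylphenyl becomes 4-bromophenyl: bromo in place of methyl on an aromatic carbon and the rest of the structure stays the same.

Going by the values given here, no pair of measured compounds shows what such an exchange does in this assay so the expectation rests on compound 3 alone, with its limit of > 100000 nM as the only anchor. No step beyond the scatter is expected in either direction, and another limit is the likeliest report. The expected step is a number no higher from compound 3 to compound 4 (the limit leaves the size open) on this estimate. The estimate for compound 4 is 100000 nM with an expected range of 30000 nM to 300000 nM on the same read-out.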

Compound 4, half-maximal inhibitory concentration: > 100000 nM
Compound 4: a limit, no number; the forecaster's own chance of this, stated with the estimate: 70%; the middle value lies on the limit itself.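

In this assay compound 4 gives > 100000 nM as a limit of the assay and not a number. Going by these compounds alone, compound 3 also stands at a limit, so no step between compound 3 and compound 4 can be read. What bromo in place of methyl does in this assay stays open, and the compounds shown mark where the reading stops: the limit of > 100000 nM in this assay, at which 2 of the 4 values shown sit.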